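The source may report more compounds than this note shows. Statements on the series, on what has been measured and on what is new or still open speak of the compounds shown alone.

Measured compounds:
Compound 1 `CN(c1ccc(Oc2ncnc3ccsc23)cc1)c1nccc(N2CCCC2)n1`: 63.6%
Compound 2 `c1ccc2c(c1)CCN2c1ccnc(Nc2ccc(Oc3ncnc4sccc34)cc2)n1`: -0.62%
Compound 3 `c1cc(N2CCCC2)nc(Nc2ccc(Oc3ncnc4ccsc34)cc2)n1`: 22.2%

Three compounds sharing a common core have been examined in a functional assay on HCT-116 cells (Homo sapiens) for inhibition, read by MTT assay, with a stated time of 72 h, tested at 20 uM; a higher number here means more inhibition at the concentration tested (going by the name of the read-out), a lower number less inhibition. Compound 1 gives 63.6% in this assay. Compound 3 gives 22.2%, and compound 2 gives -0.62%, which is the lowest of the three numbers; its nearest neighbour is compound 3, and its furthest compound 1.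

Compound 3 and compound 1 differ in a single place: methyl in place of hydrogen on a nitrogen on an aromatic ring. This change produced a step of a number 41.4 percentage points higher from compound 3 to compound 1 (beyond the scatter), a large gain that lies well beyond the usual scatter. How the core of compound 2 differs from that of compound 3 is not broken down here.

Compound 4 `CN(c1ccc(Oc2ncnc3sccc23)cc1)c1nccc(N2CCc3ccccc32)n1` has not yet been measured in this assay. It stands to compound 2 exactly as compound 1 stands to compound 3, by the same change: methyl in place of hydrogen on a nitrogen on an aromatic ring. Within this small set the change occurs twice in all, once measured and once still to be tested.

For the measured compounds named here, the expectation for compound 4 rests on the single measured instance of this change, the step from compound 3 to compound 1, a number 41.4 percentage points higher from compound 3 to compound 1 (beyond the scatter), applied to the starting point of compound 2 at -0.62%. Going by the values given here, since only one example supports it, and the surrounding core is not the same, a smaller gain is expected, estimated as a step of a number 30.6 percentage points higher from compound 2 to compound 4 (beyond the scatter) from compound 2 to compound 4. Compound 4 is therefore expected to reach about 30% in this assay, most likely between 5% and 60%.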

Compound 4, a percentage reported as inhibition, at one concentration (the size of the read-out at that concentration, not a potency): 20%
Beside the measured number, compound 4's estimate is 10 percentage points above it; the range from low to high includes it.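

In this assay, methyl in place of hydrogen on the nitrogen gave a number 20.6 percentage points higher from compound 2 to compound 4 (beyond the scatter), so the direction of the change carried over from one core to the other. The size of the step did not carry over, as the two steps stand further apart than their scatter allows: the same change on two cores in this assay, a number 41.4 percentage points higher (beyond the scatter) from compound 3 to compound 1 and a number 20.6 percentage points higher (beyond the scatter) from compound 2 to compound 4, 20.8 percentage points apart, beyond the scatter of two such steps With only these two pairs, the result shows that the gain depends on the surrounding core, but it does not show which part of the core matters, or what size of step a further core would give. Each number is also a reading at a single concentration, so neither step describes a change in potency.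

The compounds shown carry only hydrogen or methyl on this nitrogen, which leaves open whether an ethyl group, a longer chain or an acetyl group there would raise the number further or lower it. The two cores also differ in more than one place, and no compound shown separates those differences, so it remains open which of them goes with the larger step and which with the smaller one.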